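Removing the acyl cap from compound 2

The source may report more compounds than this note shows. Statements on the series, on what has been measured and on what is new or still open speak of the compounds shown alone.

Compound 2 `CCCCOC(=O)CNC(=O)[C@H](CSc1ccc([N+](=O)[O-])cc1[N+](=O)[O-])NC(=O)CC[C@H](NC(=O)CCC(C)C)C(=O)OCCCC` is one of two close analogues; in a toxicity assay on KB cells (Homo sapiens) for cytotoxicity, read by fluorescence, with a stated time of 3 days (a lower number here means that less compound is needed, a higher number that more compound is needed for the effect), compound 2 gives 84 uM. Compound 1 `CCCCOC(=O)CNC(=O)[C@H](CSc1ccc([N+](=O)[O-])cc1[N+](=O)[O-])NC(=O)CC[C@H](NC(=O)CC(C)C)C(=O)OCCCC` carries the acyl group that is shorter by one carbon, and in this assay compound 1 gives 59.6 uM. Among the compounds with values here, the only step between measured compounds, a 1.4-fold higher number from compound 1 to compound 2 (0.15 log units; within the scatter), is small and within the scatter, so compound 2 stands at the higher of the two numbers without any real separation from compound 1. Compound 3 `CCCCOC(=O)CNC(=O)[C@H](CSc1ccc([N+](=O)[O-])cc1[N+](=O)[O-])NC(=O)CC[C@H](N)C(=O)OCCCC` goes further: hydrogen in place of isopentylcarbonyl on an amine nitrogen. Within the data shown here, no measured step removes the cap, so the one known step gives only weak guidance; it shows that changing the cap by one carbon leaves the number essentially unchanged. He therefore expects at most a modest shift in this assay for compound 3, with the wide uncertainty of an untested change, and estimates 90 uM, between 35 uM and 250 uM, a step of a 1.1-fold higher number from compound 2 to compound 3 (0.03 log units; within the scatter).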

Compound 3, concentration for half-maximal effect: 107 uM
Compound 3: middle estimate off by 1.2-fold (0.08 log units), on the low side; the measured number falls inside the stated range.
By their numbers in this assay, from the lowest: compounds 1, 2 and 3 (each within the scatter of the next).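

Taking the cap off altogether, rather than trimming it by one carbon, still gives no separation on this amine nitrogen in this assay: hydrogen in place of isopentylcarbonyl gives a 1.3-fold higher number from compound 2 to compound 3 (0.11 log units; within the scatter), and hydrogen in place of isobutylcarbonyl gives a 1.8-fold higher number from compound 1 to compound 3 (0.25 log units; within the scatter). Compound 3 therefore shows that, across these three compounds, the free amino form cannot be told apart from either acylated form, so neither acyl group can be said to matter for this number. Nothing available here offers an explanation for this result.

On these data alone, it remains open whether an acyl group of another kind on this nitrogen, such as benzoyl or a much longer chain, would move the number beyond the scatter. As far as these compounds go, it is equally open whether the amino form would behave the same way with a carboxylic acid in place of the butyl esters.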